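Methoxybenzyl in Place of Carbamoylmethyl on the Shared Core

The compounds below may be only part of what the source reports. "The series", "measured", "known", "first", "only" and "open" are said of these compounds alone.

Compound 2 `NC(=O)Cn1c(=O)n(C2OC(CO)[C@@H](O)[C@H]2O)c2nc(N)nc(O)c21` stands highest of the two compounds measured in a functional assay on the whole organism with Mus musculus as the target (a lower number here means a smaller maximal response, a higher number a larger maximal response), where compound 2 reaches 72%. Its nearest neighbour, compound 1 `C=CCn1c(=O)n(CCCCO)c2nc(N)nc(O)c21`, gives 16% in this assay, a gap that lies beyond the scatter. Compound 3 `COc1ccc(Cn2c(=O)n(C3OC(CO)[C@@H](O)[C@H]3O)c3nc(N)nc(O)c32)cc1` keeps the shared core and differs from compound 2 in one place: 4-methoxyphenyl in place of carbamoyl on a saturated chain carbon bound to an aromatic nitrogen. Among the compounds with values here, no measured pair shows a change of this kind, so neither direction is backed by the numbers in hand. A moderate fall is expected, a step of a number 22 percentage points lower from compound 2 to compound 3 (beyond the scatter). Compound 3 is estimated to reach 50%, with a likely range from 20% to 80%.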

Compound 3, largest response reached (reported as maximal response), in percent of the reference or control that the assay uses: 14%
Beside the measured number, compound 3's estimate is 36 percentage points above it; the measured number lies below the stated range.
By their numbers in this assay, from the lowest: compounds 3 and 1 (each within the scatter of the next); then compound 2.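

On the shared core, 4-methoxyphenyl in place of carbamoyl on a saturated chain carbon bound to an aromatic nitrogen gives, in this assay, a number 58 percentage points lower from compound 2 to compound 3 (beyond the scatter). This position therefore does not tolerate every group in this read-out, and of the two groups compared here, carbamoylmethyl goes with the larger maximal response. Nothing at hand accounts for the size of this step. On these data alone, whether the fall tracks the loss of carbamoyl or the arrival of 4-methoxyphenyl stays open. A plain benzyl, a carboxylic acid or an amine at this place could separate the two.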